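Working notes on a polycyclic ester series

The source may hold more compounds than are shown below. What is called first, only, known or untested is meant among the compounds shown, and "the series" means these compounds.

Measured so far:
compound 1 `CC1=CC[C@H]2[C@@H]1CC=C(C)[C@@H](CCC1=C(C)CC[C@@H]3OC(C)(C)[C@@H](O)CC[C@@]13C)C2(C)C`: > 50000 nM
compound 2 `CC1=CC[C@H]2[C@@H]1CC=C(C)[C@@H](CC[C@H]1[C@]3(C)CC[C@H](OC(=O)c4ccc(C)cc4)C(C)(C)O[C@H]3CC[C@@]1(C)O)C2(C)C`: > 50000 nM
compound 3 `CC1=CC[C@H]2[C@H](CC[C@]2(C)O)C(C)(C)[C@@H]1CC[C@H]1[C@]2(C)CC[C@H](OC(=O)NCc3ccccc3)C(C)(C)O[C@H]2CC[C@@]1(C)O`: 24500 nM

In a functional assay on MCF7 cells (Homo sapiens) for antiproliferative activity, read by MTT assay, with a stated time of 72 h (a higher number here means a weaker inhibitor, a lower number a stronger inhibitor), compound 1 gives > 50000 nM, which is a limit of the assay and not a number. Compound 2 likewise gives > 50000 nM in this assay, again only a limit. Among the compounds with values here, compound 3 gives 24500 nM in this assay and is the single compound with a numerical read-out; the other two sit at the limit of > 50000 nM in this assay, at which 2 of the 3 values shown sit. Within the data shown here, no step between measured compounds that differ in one place exists here, so compound 3 is the sole anchor.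

Compound 4 `CC1=CC[C@H]2[C@H](CC[C@]2(C)O)C(C)(C)[C@@H]1CC[C@H]1[C@]2(C)CC[C@H](OC(=O)c3ccco3)C(C)(C)O[C@H]2CC[C@@]1(C)O` is the next compound for this assay. Its difference from compound 3: furan-2-yl in place of benzylamino on a carbonyl carbon.

Among the measured compounds shown here, with no measured step of this kind available, the expectation rests on compound 3 alone. The step from compound 3 to compound 4 is expected to be small, a 1.3-fold higher number from compound 3 to compound 4 (0.12 log units; within the scatter), no more than the usual scatter or a modest weakening. Compound 4 is therefore estimated at 32000 nM, within a range of 10000 nM to 80000 nM, with a real chance that only a limit is reported.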

Compound 4, half-maximal inhibitory concentration: 25700 nM
The estimate for compound 4 lay 1.2-fold (0.10 log units) above the measured number, and the stated range covers the measured number.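

In this assay, putting furan-2-yl in place of benzylamino on a carbonyl carbon gives a 1.0-fold higher number from compound 3 to compound 4 (0.02 log units; within the scatter). Within the data shown here, this is the only step at this position that can be read, and it gives the series a second numerical read-out on the same core. The exchange replaces a six-membered aromatic ring of carbon only and a hydrogen-bond donor with a five-membered aromatic ring and a hydrogen-bond acceptor, yet the two compounds cannot be told apart in this read-out.

On these data alone, whether dimethylamino or a longer alkyl chain on this carbonyl carbon would shift the number beyond the scatter remains open. Compound 1 and compound 2 form no readable step, each being recorded only as a limit and not a number: the limit of > 50000 nM in this assay, at which 2 of the 4 values shown sit.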